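The compounds below may be only part of what the source reports. "The series", "measured", "known", "first", "only" and "open" are said of these compounds alone.

Compound 1 `CC(C)(C)OC(=O)N1CCN(C(=O)Nc2ccc(C(F)(F)F)cc2)C(c2ccccc2)C1` gives 42100 nM in an ADME assay on A549 cells (Homo sapiens) for cytotoxicity, read by resazurin assay, with a stated time of 48 h (on this read-out lower numbers stand for higher toxicity in this test and higher numbers for lower toxicity in this test), and compound 2 `CC(C)(C)OC(=O)N1CCN(C(=O)Nc2ccc(C#N)cc2)C(c2ccccc2)C1` gives 91300 nM. The step of a 2.2-fold higher number from compound 1 to compound 2 (0.34 log units; beyond the scatter) is the only measured one, so compound 2 has the highest of the two numbers. Compound 3 `COc1ccc(NC(=O)N2CCN(C(=O)OC(C)(C)C)CC2c2ccccc2)cc1` carries the change (methoxy in place of cyano on an aromatic carbon). Among the compounds with values here, no measured step covers a methoxy group at this position; the one step available is modest and does not bear directly on it. For compound 3 in this assay no shift beyond the scatter is expected, a 1.1-fold lower number from compound 2 to compound 3 (0.06 log units; within the scatter), with an estimate of 80000 nM and a range from 30000 nM to 200000 nM.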

Compound 3, half-maximal cytotoxic concentration: 133000 nM
Beside the measured number, compound 3's estimate is 1.7-fold (0.22 log units) below it; the range from low to high includes it.
By their numbers in this assay, from the lowest: compound 1; then compounds 2 and 3 (each within the scatter of the next).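

Methoxy, on an aromatic carbon para to a large group, reads level with cyano in this assay (a 1.5-fold higher number from compound 2 to compound 3 (0.16 log units; within the scatter)). Against trifluoromethyl the same group gives a clear step (a 3.2-fold higher number from compound 1 to compound 3 (0.50 log units; beyond the scatter)), so among these three compounds only compound 1 stands apart, on the lower side. Nothing available bears on the cause of this.

Still open, on these data alone, is how an amine or a carboxylic acid at this position would read in this assay. Also open, as far as these compounds go, is whether a longer chain in place of methoxy would stay level with compound 2 and compound 3.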